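Adding a fluoro group to compound 2

The source may report more compounds than this note shows. Statements on the series, on what has been measured and on what is new or still open speak of the compounds shown alone.

Compound 1 `O=c1[nH]ccn1CCOc1nn(-c2ccccc2F)c2ccc(F)cc12`: 35%
Compound 2 `O=C1NCCN1CCOc1nn(-c2ccccc2F)c2ccc(F)cc12`: 17%

Both values come from an ADME assay on the whole organism (strain Sprague-Dawley) for pharmacokinetics, with Rattus norvegicus as the target, read by LC-MS; a lower number here means that a smaller share of the oral dose reaches the circulation, a higher number that a larger share of the oral dose reaches the circulation. Of these two numbers, the lower belongs to compound 2, and the gap between them is a number 18 percentage points lower from compound 1 to compound 2 (beyond the scatter).

The next compound, compound 3 `O=C1NCCN1CCOc1nn(-c2ccc(F)cc2F)c2ccc(F)cc12`, differs from compound 2 in one place: fluoro in place of hydrogen on an aromatic carbon. Fluoro replaces hydrogen on an aromatic carbon, turning 2-fluorophenyl into 2,4-difluorophenyl.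

Among the compounds with values here, the only measured step, a number 18 percentage points lower from compound 1 to compound 2 (beyond the scatter), involves a different part of the molecule, the five-membered ring on the chain. Within the data shown here, it therefore offers no direct guide to this change, and no measured step shows what adding fluoro does here. With no evidence for a direction, no shift beyond the scatter is expected, and the expected step is a number 3 percentage points higher from compound 2 to compound 3 (within the scatter). The estimate for compound 3 is 20%, with an expected range from 8% to 35%.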

Compound 3, oral bioavailability: 71%
Beside the measured number, compound 3's estimate is 51 percentage points below it, and the stated range ends below it.
By their numbers in this assay, from the lowest: compound 2; then compound 1; then compound 3.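

In this assay, fluoro in place of hydrogen on this aromatic carbon, para to a large group, gives a number 54 percentage points higher from compound 2 to compound 3 (beyond the scatter). The position is therefore highly sensitive, since one added atom that turns 2-fluorophenyl into 2,4-difluorophenyl produces a large change. The non-aromatic five-membered ring of compound 2 is also kept in compound 3, which reaches 71%, so that ring does not by itself hold the number low, and nothing measured here explains why the fluoro has this effect.

The compounds shown leave open whether the gain is specific to fluoro or would also appear with another group at this position, such as chloro, methoxy or nitrile. They also leave open whether the same fluoro would raise the number in compound 1, which carries the aromatic five-membered ring.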